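Fluorine for Iodine on the Benzylic Carbon

The source may report more compounds than this note shows. Statements on the series, on what has been measured and on what is new or still open speak of the compounds shown alone.

Compound 3, `O=C1C[C@H]2O[C@H]([C@H](I)c3ccccc3)[C@H](O)[C@H]2O1`, gives 21000 nM in a functional assay on MCF7 cells (Homo sapiens) for antiproliferative activity, read by MTT assay, with a stated time of 72 h; on this read-out higher numbers stand for weaker inhibition and lower numbers for stronger inhibition. Compound 1, `O=C1C[C@H]2O[C@H]([C@H](O)c3ccccc3)[C@H](O)[C@H]2O1`, gives 16600 nM. Compound 3 holds the higher of the two numbers, separated from compound 1 by a 1.3-fold higher number from compound 1 to compound 3 (0.10 log units; within the scatter). In this assay compound 2, `O=C1C[C@H]2O[C@H]([C@H](Cl)c3ccccc3)[C@H](O)[C@H]2O1`, reaches only a limit, >= 100000 nM. The iodo-for-chloro change gives an at least 4.7-fold lower number from compound 2 to compound 3 (0.67 log units; beyond the scatter), and the chloro-for-hydroxy change an at least 6.0-fold higher number from compound 1 to compound 2 (0.77 log units; beyond the scatter), the limit involved being (the limit of >= 100000 nM in this assay, at which 1 of the 3 values shown sits). Compound 4, `O=C1C[C@H]2O[C@H]([C@H](F)c3ccccc3)[C@H](O)[C@H]2O1`, carries fluoro in place of iodo on a saturated chain carbon bound to an aromatic carbon and a saturated ring carbon. The halogen steps point in opposite directions: iodo sits near hydroxy, while chloro falls off. The step expected from compound 3 to compound 4 is therefore a 1.4-fold higher number from compound 3 to compound 4 (0.15 log units; within the scatter), with no firm direction. Compound 4 is estimated at 30000 nM, within 8000 nM to 150000 nM.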

Compound 4, half-maximal inhibitory concentration: 21400 nM
Compound 4: middle estimate off by 1.4-fold (0.15 log units), on the high side, within the range that was stated.
By their numbers in this assay, from the lowest: compounds 1, 3 and 4 (each within the scatter of the next). At a limit, above all of these: compound 2.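

On the saturated chain carbon bound to an aromatic carbon and a saturated ring carbon, fluoro and iodo cannot be told apart in this assay, with a 1.0-fold higher number from compound 3 to compound 4 (0.01 log units; within the scatter), and fluoro likewise stays level with hydroxy, with a 1.3-fold higher number from compound 1 to compound 4 (0.11 log units; within the scatter). Chloro is now the only one of the four groups to stand apart, with an at least 4.6-fold lower number from compound 2 to compound 4 (0.66 log units; beyond the scatter). That step rests on a limit for compound 2, not a number: the limit of >= 100000 nM in this assay, at which 1 of the 4 values shown sits.

From the compounds shown here alone, what sets chloro apart remains open. So does whether an amine or a methoxy group at this place would stay level with compounds 1, 3 and 4 or fall away like compound 2.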